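Adding two methyl groups to the amine of compound 3

The source may hold more compounds than are shown below. What is called first, only, known or untested is meant among the compounds shown, and "the series" means these compounds.

Measured in a functional assay on MCF7 cells (Homo sapiens) for antiproliferative activity, read by MTT assay, with a stated time of 48 h (on this read-out higher numbers stand for weaker inhibition and lower numbers for stronger inhibition), for three compounds
- compound 1 `COc1ccc(C(=O)c2ccc(OC)c3c2C=CC(C)(C)O3)c(NC(=O)CBr)c1` gives 3290 nM
- compound 2 `CCNCC(=O)Nc1cc(OC)ccc1C(=O)c1ccc(OC)c2c1C=CC(C)(C)O2` gives 7230 nM
- compound 3 `C=C(c1cc(OC)c(OC)c(OC)c1)c1ccc(OC)cc1NC(=O)CN` gives 190 nM

Compound 3 has the lowest number of the three, and so is the strongest inhibitor here. Its value (190 nM) lies well beneath those of compound 1 (3290 nM) and compound 2 (7230 nM), which share a core different from that of compound 3.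

Compound 4 `C=C(c1cc(OC)c(OC)c(OC)c1)c1ccc(OC)cc1NC(=O)CN(C)C` has dimethylamino in place of amino on a saturated chain carbon bound to a carbonyl carbon. No measurement shows this exact swap. Among the measured compounds shown here, the only measured step at this chain carbon is a 2.2-fold higher number from compound 1 to compound 2 (0.34 log units; beyond the scatter), where ethylamino replaces bromo on the other core. That step is modest but beyond the scatter, so it is weak evidence for a modest rise here as well.

The expected change in this assay is a 1.8-fold higher number from compound 3 to compound 4 (0.27 log units; within the scatter), a modest weakening that remains uncertain. Compound 4 is estimated at 350 nM, with an expected range of 100 nM to 1300 nM.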

Compound 4, half-maximal inhibitory concentration: 390 nM
Compound 4: the middle estimate sits 1.1-fold (0.05 log units) below what was measured, within the range that was stated.
By their numbers in this assay, from the lowest: compound 3; then compound 4; then compound 1; then compound 2.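

In this assay the core of compound 3 now has its own measured step at this chain carbon: a 2.1-fold higher number from compound 3 to compound 4 (0.31 log units; beyond the scatter). Dimethylamino in place of amino, with hydrogen-bond donors going from 1 to 0, therefore gives a modest weakening that is beyond the usual scatter, and it points the same way as the one earlier step at this carbon, though that step replaced bromo on a different core. No available measurement explains the rise.

The compounds shown leave open whether methylamino, with a single methyl group, would read closer to compound 3 or to compound 4. Also open, going by these compounds, is how diethylamino, a longer chain or a carboxylic acid would read at this saturated chain carbon bound to a carbonyl carbon.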